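This account rests on a few compounds, and the source may have more. Where it says the series, first, only, none or still open, it means among the compounds named here.

The measured compounds and their values in an ADME assay on HeLa cells (Homo sapiens) for cytotoxicity, read by MTT assay, with a stated time of 72 h (on this read-out lower numbers stand for stronger inhibition of growth and higher numbers for weaker inhibition of growth), are these. Compound 1 `O=C(/C=C\c1cccc(O)c1)N1N=C(c2ccncc2)OC1c1c[nH]c2ccccc12` gives > 30 ug/mL, a limit of the assay. Compound 2 `O=C(/C=C\c1cccc([N+](=O)[O-])c1)N1N=C(c2ccncc2)OC1c1c[nH]c2ccccc12` gives > 30 ug/mL, also a limit. Compound 3 `O=C(/C=C\c1ccc([N+](=O)[O-])cc1)N1N=C(c2ccncc2)OC1c1c[nH]c2ccccc12` gives > 30 ug/mL, again a limit.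

Compound 3 thus stands at the assay limit, where every measured compound sits (the limit of > 30 ug/mL in this assay, at which 3 of the 3 values shown sit). Compound 4 `COc1ccc(/C=C\C(=O)N2N=C(c3ccncc3)OC2c2c[nH]c3ccccc23)cc1` differs from compound 3 by methoxy in place of nitro on an aromatic carbon, para to a large group. The steps a step that the two limits leave unreadable from compound 1 to compound 2, a step that the two limits leave unreadable from compound 1 to compound 3 and a step that the two limits leave unreadable from compound 2 to compound 3 all run between two limits, so their size cannot be read, and none of them exchanges a nitro for a methoxy. Going by the values given here, they give no ground for a step in this assay beyond the scatter. The step that the limit leaves unreadable from compound 3 to compound 4 is estimated as none beyond the scatter. Compound 4 is expected to give 35 ug/mL, within 18 ug/mL to 70 ug/mL.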

Compound 4, concentration for 50% growth inhibition: > 30 ug/mL
Compound 4: a limit, no number (the forecaster's own chance of this, stated with the estimate: 80%); the middle value lies beyond the limit too.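

Going by these compounds alone, compound 4 stands at a limit, as do compound 1, compound 2 and compound 3, so no step from any of them to compound 4 can be read: the limit of > 30 ug/mL in this assay, at which 4 of the 4 values shown sit. The compounds shown leave open whether any exchanged group changes growth inhibition in this assay.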